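Reversing an Amide: Expected Lipophilicity of Compound 4

The source may hold more compounds than are shown below. What is called first, only, known or untested is meant among the compounds shown, and "the series" means these compounds.

compound 1 `O=C(Nc1ccccc1)c1cnc(NCc2c(F)ccc3c2CCO3)n2cnnc12`: 4.1
compound 2 `Cn1cc(-c2cnc(NCc3c(F)ccc4c3CCO4)c3cn[nH]c(=O)c23)cn1`: 2.7
compound 3 `Cc1nc(CO)ccc1-c1cnc(NCc2c(F)ccc3c2CCO3)c2cn[nH]c(=O)c12`: 2.4

In a physicochemical assay for lipophilicity, using the shake flask method, in phosphate buffer, measured as octanol-water partition, with a stated time of 30 min, at pH 7.4 (on this read-out lower numbers stand for lower lipophilicity and higher numbers for higher lipophilicity), compound 1 gives the highest of the three numbers; compound 2 and compound 3 both sit well below it, on a different core. Compound 4 `O=C(Nc1cnc(NCc2c(F)ccc3c2CCO3)n2cnnc12)c1ccccc1` differs from compound 1 only by benzamido in place of phenylcarbamoyl on an aromatic carbon; the two share the same atoms, joined differently. For the measured compounds named here, the single measured step, a number 0.30 log units lower from compound 2 to compound 3 (within the scatter), concerns another change on another core and offers no direct guide here. With no group added or removed, the step of a number 0.20 log units lower from compound 1 to compound 4 (within the scatter) is expected to stay within the scatter. Compound 4 is therefore estimated at 3.9, within a range from 3.3 to 4.5.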

Compound 4, distribution coefficient: 3
Compound 4: middle estimate off by 0.90 log units, on the high side; the measured number lies below the stated range.
By their numbers in this assay, from the lowest: compounds 3, 2 and 4 (each within the scatter of the next, the first and the last beyond it); then compound 1.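

In this assay, the direction of the amide at this position matters: a number 1.10 log units lower from compound 1 to compound 4 (beyond the scatter) with benzamido in place of phenylcarbamoyl. The atoms stay the same, so the way they are joined is enough to move this read-out on the shared core. Nothing measured here explains why the two arrangements differ.
From the compounds shown here alone, whether an added amine or carboxylic acid on the benzamido ring, or a longer chain in place of that ring, would shift the number further remains open. So does whether reversing the amide would have a step of similar size on another core.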